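The compounds below may be only part of what the source reports. "The series", "measured", "known", "first", "only" and "open" are said of these compounds alone.

Measured so far:
compound 1 `O=C(Nc1ccc(Sc2nc3ccccc3s2)cc1)c1ccccc1`: > 100000 nM
compound 2 `O=C(Nc1ccc(Sc2nc3ccccc3s2)c(Cl)c1)c1ccccc1O`: > 100000 nM

In an assay for inhibition of HSP60/HSP10 (Homo sapiens), with a stated time of 60 min (on this read-out lower numbers stand for stronger inhibition and higher numbers for weaker inhibition), compound 2 gives > 100000 nM, which is a limit of the assay rather than a number. Compound 1 likewise reaches only > 100000 nM, also a limit. Compound 2 therefore stands at the limit of > 100000 nM in this assay, at which 2 of the 2 values shown sit, and its position relative to compound 1 cannot be told. Compound 3 `O=C(Nc1ccc(Sc2nc3ccccc3s2)c(Cl)c1)c1ccccc1` differs from compound 2 by hydrogen in place of hydroxy on an aromatic carbon. Going by the values given here, no measured pair shows this change, so no step beyond the scatter is expected in this assay. For compound 3 the expected result is 150000 nM, with a range of 30000 nM to 1000000 nM, most probably again only a limit. The step this estimate implies is a step that the limit leaves unreadable from compound 2 to compound 3, expected to stay within the scatter.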

Compound 3, half-maximal inhibitory concentration: > 100000 nM
Compound 3: only a limit was reported; the forecaster's own chance of this, stated with the estimate: 85%; the middle value is on the limit's open side.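

In this assay, going by these compounds alone, compound 3 gives > 100000 nM, which is a limit, so no step from compound 1 or compound 2 to compound 3 can be read. Whether the hydroxy or chloro group changes inhibition stays open, because all values share one limit: the limit of > 100000 nM in this assay, at which 3 of the 3 values shown sit.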